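The compounds below may be only part of what the source reports. "The series", "measured", "known", "first", "only" and "open" are said of these compounds alone.

Measured so far:
compound 1, `Fc1cccc(-c2n[nH]cc2N2CCCNCC2)c1`, 841 nM;
compound 2, `Fc1ccc(-c2n[nH]cc2N2CCCNCC2)cc1`, 2290 nM;
compound 3, `COc1cccc(-c2n[nH]cc2N2CCCNCC2)c1`, > 10000 nM.

All three were tested in an assay on isolated protein for binding affinity to 5-hydroxytryptamine receptor 6 (Homo sapiens); a higher number here means a weaker inhibitor, a lower number a stronger inhibitor. Compound 1 and compound 2 are built from the same atoms joined differently; the difference between the two cores is not broken down here. Of the two numbers, compound 2 gives the higher one, and its gap to compound 1 lies beyond the usual scatter.

Compound 3 sits at a limit of this assay and is not a number. The change from compound 1 to compound 3 is methoxy in place of fluoro on an aromatic carbon, and it brought an at least 11-fold higher number from compound 1 to compound 3 (1.07 log units; beyond the scatter); the step can only be given as a lower bound because compound 3 sits at the limit of > 10000 nM in this assay, at which 1 of the 3 values shown sits.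

The compound not yet measured is compound 4, `COc1ccc(-c2n[nH]cc2N2CCCNCC2)cc1`. It differs from compound 2 by methoxy in place of fluoro on an aromatic carbon. This is the same kind of change as that from compound 1 to compound 3, though the surroundings differ: there the group sat meta to a large group, here it sits para to a large group. Resting on the measured step of an at least 11-fold higher number from compound 1 to compound 3 (1.07 log units; beyond the scatter), and starting from the higher value of compound 2, the account expects a 7.9-fold higher number from compound 2 to compound 4 (0.90 log units; beyond the scatter). Compound 4 is thus estimated at 18000 nM, within 5000 nM to 70000 nM, most likely beyond what the assay can report as a number.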

Compound 4, inhibition constant: > 10000 nM
Compound 4 gave a limit, no number; the forecaster's own chance of this, stated with the estimate: 65%; the middle value is on the limit's open side.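

In this assay compound 4 gives > 10000 nM, which is a limit of the assay and not a number. Methoxy in place of fluoro on an aromatic carbon therefore brought an at least 4.3-fold higher number from compound 2 to compound 4 (0.64 log units; beyond the scatter), a rise in the same direction as on the core of compound 1, though the two sizes cannot be set against each other: the same change on two cores in this assay, an at least 11-fold higher number (1.07 log units; beyond the scatter) from compound 1 to compound 3 and an at least 4.3-fold higher number (0.64 log units; beyond the scatter) from compound 2 to compound 4; the limit leaves it open whether they differ So the direction of the change carried from one core to the other in this pair of steps, but these data do not show that its size carried over, since compound 3 and compound 4 stand at one and the same limit: the limit of > 10000 nM in this assay, at which 2 of the 4 values shown sit.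

The compounds shown leave open how far the number rises with methoxy on either core, as neither methoxy compound has a value that is a number. They also leave open how a chloro, methyl, trifluoromethyl or hydroxyl group would read on the same aromatic carbon, and whether any of these would stay closer to the fluoro compounds than methoxy does.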